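The source may hold more compounds than are shown below. What is called first, only, known or untested is meant among the compounds shown, and "the series" means these compounds.

Measured compounds in a functional assay on LCLC-103H cells (Homo sapiens) for cytotoxicity, with a stated time of 96 h; on this read-out lower numbers stand for stronger inhibition of growth and higher numbers for weaker inhibition of growth:

- compound 1 `COC(=O)c1cc2c(cc1Cl)SC(N(N(C)C)S(=O)(=O)c1ccc(Cl)cc1)=NS2(=O)=O` — 19600 nM
- compound 2 `O=C(Oc1cccc2cccnc12)c1cc2c(cc1Cl)SC(N(c1ccc(F)cc1)S(=O)(=O)c1ccc(Cl)cc1)=NS2(=O)=O` — 4600 nM
- compound 3 `CCOC(=O)c1cc2c(cc1Cl)SC(N(c1ccc(F)cc1)S(=O)(=O)c1ccc(OC)cc1)=NS2(=O)=O` — 17500 nM

Compound 1 carries the highest number of the three in this assay. Compound 3 sits close to it, and the gap between compound 1 and compound 3 lies within the usual scatter, so no order between them can be read. Compound 2 gives the lowest number, and its gap to compound 1 is beyond the scatter. Among the compounds with values here, no pair of these measured compounds differs in a single place, so no step size between measured compounds is available.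

Compound 4 `Cc1cc2c(cc1Cl)SC(N(N(C)C)S(=O)(=O)c1ccc(Cl)cc1)=NS2(=O)=O` is not yet measured. It differs from compound 1 in one place: methyl in place of methoxycarbonyl on an aromatic carbon

With no measured step of this kind in the set, the expectation for compound 4 rests only on the position of compound 1. In this assay the estimated step is a 1.3-fold higher number from compound 1 to compound 4 (0.11 log units; within the scatter). Compound 4 is therefore estimated at 25000 nM, with a range from 8000 nM to 80000 nM.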

Compound 4, concentration for 50% growth inhibition: > 20000 nM
Compound 4 was reported as a limit (the forecaster's own chance of this, stated with the estimate: 20%); the middle value is on the limit's open side.
By their numbers in this assay, from the lowest: compound 2; then compounds 3 and 1 (each within the scatter of the next). At a limit, above all of these: compound 4.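

In this assay, compound 4 is reported only as a limit, > 20000 nM. The change from methoxycarbonyl to methyl on this aromatic carbon, ortho to the chloro group, reads as an at least 1.0-fold higher number from compound 1 to compound 4 (0.00 log units; that floor lies within the scatter), so it gives a lower bound and no exact size. This is the first one-place change in the series, and it shows no gain in growth inhibition from methyl at this position, while how far compound 4 lies from compound 1 stays unresolved: the limit of > 20000 nM in this assay, at which 1 of the 4 values shown sits.

Still open, as far as these compounds go, is how a carboxylic acid or a primary amide on this aromatic carbon would read on the core of compound 1. Also open, from the compounds shown here alone, is whether methyl in place of the ester would read the same way in compound 2 or compound 3.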